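Methyl for methoxy on the anilino ring of compound 1

This account rests on a few compounds, and the source may have more. Where it says the series, first, only, none or still open, it means among the compounds named here.

For the measured compounds named here, compound 1 `COc1ccc(Nc2cc(C)nc(SCc3nc4ccccc4[nH]3)n2)cc1` is the one member of the series with a number rather than a limit in a functional assay on MCF7 cells (Homo sapiens) for cytotoxicity, read by MTT assay, with a stated time of 72 h; on this read-out lower numbers stand for stronger inhibition and higher numbers for weaker inhibition: compound 1 gives 61100 nM. Compound 2 `Cc1cc(NNC(N)=S)nc(SCc2nc3ccccc3[nH]2)n1` reaches only the assay limit, > 100000 nM. Compound 3 `COc1ccccc1Nc1cc(C)nc(SCc2nc3ccccc3[nH]2)n1` also sits at the assay limit, > 100000 nM. This is the limit of > 100000 nM in this assay, at which 2 of the 3 values shown sit. The measured steps are thus floors: an at least 1.6-fold higher number from compound 1 to compound 2 (0.21 log units; that floor lies within the scatter), an at least 1.6-fold higher number from compound 1 to compound 3 (0.21 log units; that floor lies within the scatter), and a step that the two limits leave unreadable from compound 2 to compound 3. Compound 4 `Cc1ccc(Nc2cc(C)nc(SCc3nc4ccccc4[nH]3)n2)cc1` differs from compound 1 by methyl in place of methoxy on an aromatic carbon. Going by the values given here, no measured step touches this exchange; both known steps replace the whole 4-methoxyphenyl group on the ring nitrogen, and both floors lie within the scatter. The expected step is therefore none beyond the scatter, a 1.1-fold higher number from compound 1 to compound 4 (0.06 log units; within the scatter). Compound 4 is estimated at 70000 nM, between 30000 nM and 150000 nM, with a real chance of only a limit.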

Compound 4, half-maximal inhibitory concentration: 56500 nM
Compound 4: the middle estimate sits 1.2-fold (0.09 log units) above what was measured; low and high end bracket the measured number.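

In this assay, methyl in place of methoxy gives a 1.1-fold lower number from compound 1 to compound 4 (0.03 log units; within the scatter), so at this place, para to a large group, the read-out does not separate the two groups. The comparisons with the other compounds are only floors, an at least 1.7-fold lower number from compound 3 to compound 4 (0.24 log units; that floor lies within the scatter) and an at least 1.7-fold lower number from compound 2 to compound 4 (0.24 log units; that floor lies within the scatter). Neither floor shows a step beyond the scatter, and their size is capped by the assay limit: the limit of > 100000 nM in this assay, at which 2 of the 4 values shown sit.

Going by these compounds, whether an amine, a carboxylic acid or a chlorine at this place would move the number beyond the scatter remains open. The shown compounds also leave open whether any change to the shared core would do so.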